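This account rests on a few compounds, and the source may have more. Where it says the series, first, only, none or still open, it means among the compounds named here.

Compound 1 (`CCCCc1ccc2[nH]c(-c3ccc(C)cc3)c(C=C(C#N)C#N)c2c1`): 65 nM
Compound 2 (`CCCCc1ccc2[nH]c(-c3ccc(CC)cc3)c(C=C(C#N)C#N)c2c1`): 76 nM

Both numbers come from a functional assay on MDA-MB-231 cells (Homo sapiens) for antiproliferative activity, with a stated time of 4 days; on this read-out lower numbers stand for stronger inhibition and higher numbers for weaker inhibition. Going by the values given here, compound 2 (76 nM) has only one measured neighbour, compound 1, and the two cannot be told apart: the step is a 1.2-fold higher number from compound 1 to compound 2 (0.07 log units; within the scatter). That step is methyl in place of hydrogen on a saturated chain carbon bound to an aromatic carbon, and it built the very ethyl group that is about to change.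

Compound 3 (`CCCCc1ccc2[nH]c(-c3ccc(C(F)(F)F)cc3)c(C=C(C#N)C#N)c2c1`) carries trifluoromethyl in place of ethyl on an aromatic carbon, para to a large group (trifluoromethyl in place of ethyl on an aromatic carbon). Among the compounds with values here, no measured compound carries trifluoromethyl, so this swap has no direct precedent, and a single small step is thin evidence. That one step is still all there is to go on, so no shift beyond the scatter is expected in this assay, and no direction can be favoured. The expected change is a 1.1-fold higher number from compound 2 to compound 3 (0.02 log units; within the scatter), with wide uncertainty. For compound 3 the estimated value is 80 nM, with an expected range from 30 nM to 220 nM.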

Compound 3, half-maximal inhibitory concentration: 56 nM
Estimate against measurement, compound 3: 1.4-fold (0.15 log units) above; low and high end bracket the measured number.
By their numbers in this assay, from the lowest: compounds 3, 1 and 2 (each within the scatter of the next).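

Up to now this spot, on an aromatic carbon of a six-membered aromatic ring of carbon only and para to a large group, had held only small carbon chains, and trifluoromethyl is the first group there to carry fluorine. In this assay the exchange for ethyl gives a 1.4-fold lower number from compound 2 to compound 3 (0.13 log units; within the scatter), and the exchange for methyl gives a 1.2-fold lower number from compound 1 to compound 3 (0.06 log units; within the scatter), so methyl, ethyl and trifluoromethyl cannot be told apart at this position, even though trifluoromethyl swaps carbon-hydrogen bonds for carbon-fluorine bonds. Nothing in the data shown accounts for this flat result.

Still unknown is whether the position would stay this forgiving with a different kind of group, such as an amine, a carboxylic acid or a much longer chain. The nitrile groups and the rest of the shared core are the same in all three compounds, so these numbers cannot show how much those parts matter to the antiproliferative read-out.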